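Furan for benzofuran in a nucleoside series

The source may report more compounds than this note shows. Statements on the series, on what has been measured and on what is new or still open speak of the compounds shown alone.

Compound 2 `O=c1[nH]cnc2c1c(-c1cc3ccccc3o1)cn2[C@@H]1O[C@H](CO)[C@@H](O)[C@H]1O` and compound 1 `O=c1[nH]cnc2c1c(-c1ccco1)cn2[C@@H]1O[C@H](CO)[C@@H](O)[C@H]1O` share one core and differ by furan-2-yl in place of 1-benzofuran-2-yl on an aromatic carbon. In a functional assay on CCRF-CEM cells (Homo sapiens), read by MTT assay, with a stated time of 72 h (a lower number here means a stronger inhibitor, a higher number a weaker inhibitor), compound 2 gives > 20000 nM, which is a limit of the assay. Compound 1 gives > 20000 nM in this assay, again a limit. The step that the two limits leave unreadable from compound 2 to compound 1 therefore has no readable size. Compound 3 `CNc1ncnc2c1c(-c1cc3ccccc3o1)cn2[C@@H]1O[C@H](CO)[C@@H](O)[C@H]1O` carries the other core; the difference between the two cores is not broken down here. Compound 3 gives > 20000 nM in this assay, also a limit. For the measured compounds named here, all values so far sit at the limit of > 20000 nM in this assay, at which 3 of the 3 values shown sit. Compound 4 `CNc1ncnc2c1c(-c1ccco1)cn2[C@@H]1O[C@H](CO)[C@@H](O)[C@H]1O` differs from compound 3 by furan-2-yl in place of 1-benzofuran-2-yl on an aromatic carbon, the same change as from compound 2 to compound 1, at the same place. The step that the limit leaves unreadable from compound 3 to compound 4 is expected to be small, resting on the unreadable step that the two limits leave unreadable from compound 2 to compound 1. Compound 4 is expected at 40000 nM, between 15000 nM and 150000 nM, most likely reported as a limit once more.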

Compound 4, half-maximal inhibitory concentration: 180 nM
For compound 4 the middle estimate is 220-fold (2.35 log units) above the measured one, outside the stated range (below it).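

In this assay, furan-2-yl in place of 1-benzofuran-2-yl gives an at least 110-fold lower number from compound 3 to compound 4 (2.04 log units; beyond the scatter), so on this core the change is large. The same change on the other core cannot be read, and compound 1, which carries furan-2-yl, gives > 20000 nM, a limit of the assay, so furan-2-yl does not by itself bring a compound off the limit, and no size carries from one core to the other. The step on the first core is only a lower bound, its true size remains unknown, and most of the set stays at the limit: the limit of > 20000 nM in this assay, at which 3 of the 4 values shown sit.

Still open, going by these compounds, is how other groups on this aromatic carbon, such as thiophen-2-yl or phenyl, would read in this assay. Also open, on these data alone, is whether furan-2-yl gives a readable value on any further core.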